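Swapping the Aryl Group on the Urea Nitrogen

A few compounds are considered here, and "the series" means these few. Any claim that something is new, unique, unknown or untested is made for them only; others in the source may bear on it.

Compound 2 `O=C(Nc1ccc(F)cc1)Nn1c(-c2ccccc2)nc2ccccc2c1=O` was tested in a functional assay on the whole organism (strain albino) with Mus musculus as the target, at a dose of 100 mg/kg by the intraperitoneal route (on this read-out lower numbers stand for less inhibition and higher numbers for more inhibition at the one dose given (going by the name of the read-out)), where compound 2 gives 54%. Among the two compounds measured, compound 2 sits within the scatter of compound 1 `Cc1cccc(NC(=O)Nn2c(-c3ccccc3)nc3ccccc3c2=O)c1`, which in this assay gives 59%. Compound 3 `Cc1ccccc1NC(=O)Nn1c(-c2ccccc2)nc2ccccc2c1=O` has not yet been measured; it differs from compound 2 by 2-methylphenyl in place of 4-fluorophenyl on an amide-type nitrogen. Within the data shown here, the one measured step that bears on this, an exchange of one aryl group for another on the same amide-type nitrogen, gave a number 5 percentage points lower from compound 1 to compound 2 (within the scatter). On that basis the expected step in this assay is a number 2 percentage points higher from compound 2 to compound 3 (within the scatter), nothing beyond the scatter. Compound 3 is therefore estimated at 56%, within a range from 40% to 70%.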

Compound 3, a percentage reported as inhibition, in the whole organism at one dose (the size of the read-out at that dose, not a potency): 59%
Compound 3: the middle estimate sits 3 percentage points below what was measured; the range from low to high includes it.
By their numbers in this assay, from the lowest: compounds 2, 1 and 3 (each within the scatter of the next).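

In this assay, 2-methylphenyl in place of 4-fluorophenyl on the amide-type nitrogen gives a number 5 percentage points higher from compound 2 to compound 3 (within the scatter), while 2-methylphenyl in place of 3-methylphenyl gives no change at the digits printed from compound 1 to compound 3 (within the scatter). These three aryl groups on this nitrogen therefore cannot be told apart on this read-out. No measurement on hand offers an explanation of this result. Going by these compounds, it remains open whether a phenyl carrying an amine or a carboxylic acid, or a longer alkyl chain in place of the aryl group, would move the number beyond the scatter in this assay.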